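Swapping a Fluoro Group for a Nitro Group

The source may hold more compounds than are shown below. What is called first, only, known or untested is meant among the compounds shown, and "the series" means these compounds.

Compound 1 `CNc1cc(-c2ccc3cnn(Cc4cc(OC)cc(OC)c4)c3c2)cn(C)c1=O`: 7400 nM
Compound 2 `CNc1cc(-c2ccc3cnn(Cc4ccc(F)c(F)c4)c3c2)cn(C)c1=O`: 8400 nM

Both values come from a functional assay on SW480 cells (Homo sapiens) for antiproliferative activity; on this read-out lower numbers stand for stronger inhibition and higher numbers for weaker inhibition. On these numbers, compound 2 cannot be told apart from compound 1: the step is a 1.1-fold higher number from compound 1 to compound 2 (0.06 log units; within the scatter). Compound 3 `CNc1cc(-c2ccc3cnn(Cc4ccc(F)c([N+](=O)[O-])c4)c3c2)cn(C)c1=O` keeps the shared core, and its 3,4-difluorophenyl becomes 4-fluoro-3-nitrophenyl, with nitro in place of fluoro on an aromatic carbon.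

Among the measured compounds shown here, only one measured step bears on this change. It altered the same part of the molecule, replacing 3,5-dimethoxyphenyl with 3,4-difluorophenyl, and stayed within the scatter. For the measured compounds named here, one step is thin evidence, and no measured compound carries a nitro group. Even so, no shift beyond the scatter is expected in this assay. The expected step is a 1.1-fold lower number from compound 2 to compound 3 (0.02 log units; within the scatter). The estimated value for compound 3 is 8000 nM, with an expected range from 3500 nM to 18000 nM.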

Compound 3, half-maximal inhibitory concentration: 10100 nM
The estimate for compound 3 lay 1.3-fold (0.10 log units) below the measured number, within the range that was stated.
By their numbers in this assay, from the lowest: compounds 1, 2 and 3 (each within the scatter of the next).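

In this assay, the place that held a fluoro group also takes a nitro group, with 3 heavy atoms and 2 hydrogen-bond acceptors instead of 1 heavy atom and none, and the number stays within the scatter: a 1.2-fold higher number from compound 2 to compound 3 (0.08 log units; within the scatter). The comparison with the earlier dimethoxy compound reads the same way, with a 1.4-fold higher number from compound 1 to compound 3 (0.14 log units; within the scatter), so 3,5-dimethoxyphenyl, 3,4-difluorophenyl and 4-fluoro-3-nitrophenyl cannot be told apart on this read-out. Nothing at hand explains why these numbers stay so close.

As far as these compounds go, what stays open is whether any group at this place can move the number beyond the scatter, for example an amine or a carboxylic acid in place of the nitro group. Also open, from the compounds shown here alone, is whether a longer chain on the aromatic nitrogen, instead of the single saturated carbon, would do so.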